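From methoxy to fluoro: the step to compound 4

The source may report more compounds than this note shows. Statements on the series, on what has been measured and on what is new or still open speak of the compounds shown alone.

In a functional assay, with a stated time of 6 min (on this read-out higher numbers stand for weaker inhibition and lower numbers for stronger inhibition), compound 1 (`COc1ccc(NCn2nc(-c3ccc4c(c3)OCCO4)oc2=S)cc1`) reads 5830 nM and cannot be told apart from compound 3 (`Fc1cccc(NCn2nc(-c3ccc4c(c3)OCCO4)oc2=S)c1`) at 6620 nM within the usual scatter. Compound 2 (`CCCCCCCCCCCCCCCCNCn1nc(-c2ccc3c(c2)OCCO3)oc1=S`) reads 22900 nM on the same scale, clearly apart from both.

Compound 4 (`Fc1ccc(NCn2nc(-c3ccc4c(c3)OCCO4)oc2=S)cc1`) has not yet been measured. It differs from compound 1 by fluoro in place of methoxy on an aromatic carbon, para to a large group, which turns the 4-methoxyphenyl into a 4-fluorophenyl.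

Within the data shown here, only one measured step bears on this change. Placing 3-fluorophenyl where 4-methoxyphenyl stood on the amine nitrogen gave a 1.1-fold higher number from compound 1 to compound 3 (0.06 log units; within the scatter) and left the number essentially unmoved. Compound 4 carries its fluoro at another ring position, so this is a single, indirect precedent, but it gives no reason to expect a shift beyond the scatter in this assay here. The expected step is a 1.1-fold higher number from compound 1 to compound 4 (0.03 log units; within the scatter) and would lie within that scatter. Compound 4 is estimated at 6200 nM with an expected range from 3000 nM to 12500 nM in this measurement.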

Compound 4, half-maximal inhibitory concentration: 6480 nM
Compound 4: middle estimate off by 1.0-fold (0.02 log units), on the low side; the range from low to high includes it.
By their numbers in this assay, from the lowest: compounds 1, 4 and 3 (each within the scatter of the next); then compound 2.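

In this assay, the exchange of methoxy for fluoro on the aromatic carbon para to a large group gives a 1.1-fold higher number from compound 1 to compound 4 (0.05 log units; within the scatter), so this change now has a direct reading at this position. Moving to 4-fluorophenyl in place of 3-fluorophenyl on the amine nitrogen gives a 1.0-fold lower number from compound 3 to compound 4 (0.01 log units; within the scatter), which shows that the placement of the fluoro in these two compounds makes no measurable difference on this read-out. Nothing available accounts for these small steps or tests them by another measurement.

From the compounds shown here alone, what an amine, a carboxylic acid or a nitrile on this same aromatic carbon would do to the number remains open. Going by these compounds, it is also open how a shorter alkyl chain on the amine nitrogen would read in this assay.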